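This account rests on a few compounds, and the source may have more. Where it says the series, first, only, none or still open, it means among the compounds named here.

Of the compounds shown here, three sharing one core have so far been tested in a functional assay on HeLa cells (Homo sapiens) for inhibition, read by CCK-8 assay, with a stated time of 48 h; a lower number here means a stronger inhibitor, a higher number a weaker inhibitor. Compound 1 `COc1cc(-c2ccnc3cc(-c4ccc(Cl)cc4)nn23)cc(OC)c1OC` gives 1490 nM in this assay, and compound 2 `COc1cc(-c2ccnc3cc(-c4ccc5ccn(C)c5c4)nn23)cc(OC)c1OC` gives 187 nM. Compound 3 `COc1cc(-c2ccnc3cc(-c4ccc(-c5cnn(C)c5)cc4)nn23)cc(OC)c1OC` gives 1830 nM, the highest of the three numbers; it is set apart from compound 2 by the step of an 8.0-fold lower number from compound 1 to compound 2 (0.90 log units; beyond the scatter) taken together with its own near-identity to compound 1.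

Compound 4 `CCOC(=O)c1ccc(-c2cc3nccc(-c4cc(OC)c(OC)c(OC)c4)n3n2)cc1` follows from compound 3 by one change: ethoxycarbonyl in place of 1-methyl-1H-pyrazol-4-yl on an aromatic carbon. For the measured compounds named here, the only measured step that bears on this kind of change is a 1.2-fold higher number from compound 1 to compound 3 (0.09 log units; within the scatter), where swapping chloro for 1-methyl-1H-pyrazol-4-yl on the same aromatic carbon moved the number within the scatter. Nothing measured shows that an ethoxycarbonyl group on that carbon behaves differently, so no step beyond the scatter is expected in this assay. Compound 4 is therefore estimated at 1600 nM, in a range from 500 nM to 5000 nM, which means an expected step of a 1.1-fold lower number from compound 3 to compound 4 (0.06 log units; within the scatter).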

Compound 4, half-maximal inhibitory concentration: > 10000 nM
Compound 4 ended at the assay's limit (the forecaster's own chance of this, stated with the estimate: 10%); middle value at least 6.2-fold (0.79 log units) from the limit.
By their numbers in this assay, from the lowest: compound 2; then compounds 1 and 3 (each within the scatter of the next). At a limit, above all of these: compound 4.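

Compound 4 stands at a limit of this assay, not at a measured number: the limit of > 10000 nM in this assay, at which 1 of the 4 values shown sits. The earlier compounds shown here showed only that chloro and 1-methyl-1H-pyrazol-4-yl on this aromatic carbon, para to a large group, give numbers within the scatter of each other, whereas ethoxycarbonyl there brings an at least 5.4-fold higher number from compound 3 to compound 4 (0.73 log units; beyond the scatter) and an at least 6.7-fold higher number from compound 1 to compound 4 (0.82 log units; beyond the scatter), so this position does not accept every group alike. The hydrogen-bond donor and acceptor counts do not separate the change from compound 3 to compound 4, since they are the same for the group that leaves and the group that enters.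

The compounds shown leave open whether this step belongs to the whole ethoxycarbonyl group, to its carbonyl or to its ethyl part, which a carboxylic acid, a primary amide or a methyl ester on that carbon could separate. They also leave open how far compound 4 lies past its limit.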